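This account rests on a few compounds, and the source may have more. Where it says the series, first, only, none or still open, it means among the compounds named here.

Working notes on the series.

The benzyl ester compound 1 `CSCC[C@H](NC(=O)CN(c1nc(Cl)nc2[nH]cnc12)C1CC1)C(=O)OCc1ccccc1` is the reference point. In a functional assay on the whole organism (Tail, strain ICR) with Mus musculus as the target, in the tail flick test, with a stated time of 90 min, at a dose of 25 umol/kg by the oral route (on this read-out higher numbers stand for a stronger effect at the one dose given and lower numbers for a weaker effect), compound 1 gives 44.6%. The proline analogue compound 2 `O=C(OCc1ccccc1)[C@@H]1CCCN1C(=O)CN(c1nc(Cl)nc2[nH]cnc12)C1CC1` gives 43.3% in this assay, a number within the scatter of compound 1, so the two cannot be ordered. Going by the values given here, the free acid compound 3 `CSCC[C@H](NC(=O)CN(c1nc(Cl)nc2[nH]cnc12)C1CC1)C(=O)O` gives 14% in this assay, and the change a number 30.6 percentage points lower from compound 1 to compound 3 (beyond the scatter) is the one step beyond the scatter that has been measured. Among the three numbers, the one for compound 1 is the largest on paper, with compound 2 within the scatter of it and compound 3 well beyond.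

The unmeasured compound 4 `NC(=O)C[C@H](NC(=O)CN(c1nc(Cl)nc2[nH]cnc12)C1CC1)C(=O)OCc1ccccc1` keeps the benzyl ester of compound 1 and differs only in the side chain: carbamoyl in place of (methylsulfanyl)methyl on a saturated chain carbon, two bonds along the chain from an amide-type nitrogen and a carbonyl carbon. Among the compounds with values here, no measured step touches that position. Within the data shown here, the single large step, from compound 1 to compound 3, concerns the ester and does not bear on a side-chain change. Compounds 1 and 2, which differ in the amino acid part while both keep the benzyl ester, show numbers within the scatter of each other, which speaks for tolerance at that end. A small step in this assay, if any, is therefore expected for compound 4, with a number 6.6 percentage points lower from compound 1 to compound 4 (within the scatter) as the working guess. The estimate for compound 4 in this assay is 38%, with a range from 20% to 55%.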

Compound 4, a percentage reported as activity, at one dose (the size of the read-out at that dose, not a potency): 32.3%
The estimate for compound 4 lay 5.7 percentage points above the measured number, and the stated range covers the measured number.
By their numbers in this assay, from the lowest: compound 3; then compound 4; then compounds 2 and 1 (each within the scatter of the next).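

In this assay, going by these compounds alone, the side chain turns out not to be a silent position: the step is a number 12.3 percentage points lower from compound 1 to compound 4 (beyond the scatter) with the benzyl ester unchanged, and it is the only step beyond the scatter so far that leaves the ester alone. Carbamoyl in place of (methylsulfanyl)methyl keeps the same number of heavy atoms and adds a hydrogen-bond donor, so a change at this saturated chain carbon moves the read-out at the one dose even when the heavy-atom count stays the same, although the step is only modest in size. Nothing on hand accounts for the drop with this swap.

Open, on these data alone, is whether the step follows from the loss of the sulfur or from the entry of the carbamoyl group, which a plain alkyl chain such as n-butyl, or a chain with an amine or a carboxylic acid on that carbon, would help to separate. Also open, as far as these compounds go, is whether chain length matters, as a comparison of carbamoylmethyl with the longer 2-carbamoylethyl would show, and whether the step would keep its size with the free acid in place of the benzyl ester.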